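A few compounds are considered here, and "the series" means these few. Any claim that something is new, unique, unknown or untested is made for them only; others in the source may bear on it.

Measured so far in a functional assay on DU-145 cells (Homo sapiens) for cytotoxicity, read by ELISA, with a stated time of 4 days; on this read-out lower numbers stand for stronger inhibition and higher numbers for weaker inhibition:
- compound 1 `Cc1ccsc1-c1cc(-c2ccoc2)cc(-c2ccco2)n1`: 30400 nM
- compound 2 `Cc1ccsc1-c1cc(-c2ccc(Cl)o2)cc(-c2ccco2)n1`: 27300 nM

Compound 2 sits level with compound 1 within the scatter, so the two cannot be ranked. The unmeasured compound 3 `Cc1ccsc1-c1cc(-c2ccc(Cl)o2)cc(-c2cccc(Cl)c2)n1` keeps the 5-chlorofuran-2-yl group of compound 2 and differs at another place: 3-chlorophenyl in place of furan-2-yl, on an aromatic carbon next to the ring nitrogen. 3-chlorophenyl in place of furan-2-yl on an aromatic carbon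

For the measured compounds named here, only one measured step bears on this, and only indirectly: a 1.1-fold lower number from compound 1 to compound 2 (0.05 log units; within the scatter). It replaced furan-3-yl with 5-chlorofuran-2-yl at a different place and stayed within the scatter. Going by the values given here, no measured compound varies the furan-2-yl group, so the data give no direct guide to the size or direction of this change. A mild lean towards a lower number in this assay is expected, held loosely. The estimated step is a 1.7-fold lower number from compound 2 to compound 3 (0.23 log units; within the scatter), and it is not firmly expected to clear the scatter. For compound 3 the expected value is 16000 nM, with an estimated range of 5000 nM to 50000 nM.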

Compound 3, half-maximal inhibitory concentration: 20500 nM
The estimate for compound 3 lay 1.3-fold (0.11 log units) below the measured number; measured number inside the range.
By their numbers in this assay, from the lowest: compounds 3, 2 and 1 (each within the scatter of the next).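

In this assay, the aromatic carbon next to the ring nitrogen now has its first measured change: 3-chlorophenyl in place of furan-2-yl gives a 1.3-fold lower number from compound 2 to compound 3 (0.12 log units; within the scatter) and so does not separate the two compounds. This exchange swaps a five-membered aromatic ring with 1 hetero atom and 1 hydrogen-bond acceptor for a six-membered aromatic ring of carbon only with 0 hydrogen-bond acceptors, and the heavy-atom count of the group goes from 5 to 7, yet compound 3 at 20500 nM stays level with compound 2 at 27300 nM. No measurement available here bears on why the number holds across this change.

As far as these compounds go, it stays open whether this position would respond to a group of another kind, such as an amine, a carboxylic acid or a longer alkyl chain, and whether plain phenyl would read the same as 3-chlorophenyl. The 3-methylthiophen-2-yl group is common to all the compounds shown, so what a replacement of it would do to the number in this assay is also unknown.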